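Aryl Group Swap on a Piperazine Series

The source may report more compounds than this note shows. Statements on the series, on what has been measured and on what is new or still open speak of the compounds shown alone.

Compound 1 `CCCc1nc(-c2ccccc2)c(CNCCCN2CCN(c3cccc(C(F)(F)F)c3)CC2)o1`: 51.6%
Compound 2 `CCCc1nc(-c2ccccc2)c(CNCCCN2CCN(c3cccc(F)c3)CC2)o1`: 68.9%
Compound 3 `CCCc1nc(-c2ccccc2)c(CNCCCN2CCN(c3cccc(Cl)c3)CC2)o1`: 65.9%

In an assay on HEK293 cells for inhibition of Voltage-dependent T-type calcium channel subunit alpha-1G (Homo sapiens), read by fluorescence, tested at 10 uM (a lower number here means less inhibition, a higher number more inhibition at the concentration tested (going by the name of the read-out)), compound 3 stands second highest of the three; compound 2 lies close at a number 3 percentage points lower from compound 2 to compound 3 (within the scatter), while compound 1 sits clearly lower at a number 14.3 percentage points higher from compound 1 to compound 3 (beyond the scatter). Compound 4 `CCCc1nc(-c2ccccc2)c(CNCCCN2CCN(c3ccccc3OC)CC2)o1` differs from compound 3 by 2-methoxyphenyl in place of 3-chlorophenyl on an amine nitrogen in a ring. Among the measured compounds shown here, no measured step carries this exact change; the aryl substituent steps seen so far are a number 17.3 percentage points higher from compound 1 to compound 2 (beyond the scatter) and a number 14.3 percentage points higher from compound 1 to compound 3 (beyond the scatter), both modest, and the chloro-for-fluoro step is within the scatter. A new group on the aryl ring may therefore move the read-out modestly, direction unknown. Compound 4 is expected to give 58%, between 35% and 80%, an expected step of a number 7.9 percentage points lower from compound 3 to compound 4 (within the scatter).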

Compound 4, a percentage reported as inhibition, at one concentration (the size of the read-out at that concentration, not a potency): 41%
Compound 4: the middle estimate sits 17 percentage points above what was measured; the measured number falls inside the stated range.
By their numbers in this assay, from the lowest: compound 4; then compound 1; then compounds 3 and 2 (each within the scatter of the next).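

In this assay the 2-methoxyphenyl group gives the lowest number of the four compounds, with a number 24.9 percentage points lower from compound 3 to compound 4 (beyond the scatter), a number 27.9 percentage points lower from compound 2 to compound 4 (beyond the scatter) and a number 10.6 percentage points lower from compound 1 to compound 4 (beyond the scatter). The aryl group on this ring nitrogen can therefore take the read-out below that of the 3-(trifluoromethyl)phenyl compound, previously the lowest. Nothing available explains this drop. This change alters both the substituent and its place on the phenyl ring, and the compounds shown do not separate the two. Going by these compounds, how an unsubstituted phenyl or a nitrile-bearing phenyl would read out at this nitrogen remains open.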